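This account rests on a few compounds, and the source may have more. Where it says the series, first, only, none or still open, it means among the compounds named here.

Going by the values given here, in a functional assay on NCI-H460 cells (Homo sapiens) for cytotoxicity, read by MTT assay, with a stated time of 72 h (on this read-out higher numbers stand for weaker inhibition and lower numbers for stronger inhibition), compound 2 (`O=c1[nH]/c(=C\c2ccc(Br)o2)c(=O)[nH]/c1=C\c1cccc(Oc2ccc(F)cc2)c1`) gives 361 nM, the only actual number so far. Compound 1 (`O=c1[nH]/c(=C\c2cccs2)c(=O)[nH]/c1=C\c1cccc(Oc2ccc(F)cc2)c1`) reaches only a limit of the assay, > 1000 nM. Among the compounds with values here, the single measured step, an at least 2.7-fold lower number from compound 1 to compound 2 (0.44 log units; beyond the scatter), lies beyond the scatter and puts 5-bromofuran-2-yl in place of thiophen-2-yl. From the compounds shown here alone, its full size stays open, with the limit of > 1000 nM in this assay, at which 1 of the 2 values shown sits.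

Compound 3 (`O=c1[nH]/c(=C\c2ccc(Cl)o2)c(=O)[nH]/c1=C\c1cccc(Oc2ccc(F)cc2)c1`) carries chloro in place of bromo on an aromatic carbon. This turns 5-bromofuran-2-yl into 5-chlorofuran-2-yl and leaves the rest of the structure unchanged. The measured step bears on this only loosely, since it exchanges the whole ring system at that end, and no exchange of bromo for chloro has been measured in this series. With compound 2 at 361 nM as the anchor, no step beyond the scatter is expected in this assay, in either direction. The expected change is a 1.1-fold higher number from compound 2 to compound 3 (0.04 log units; within the scatter). For compound 3 the estimated value is 400 nM, with an expected range of 170 nM to 950 nM.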

Compound 3, half-maximal inhibitory concentration: 180 nM
Compound 3: middle estimate off by 2.2-fold (0.35 log units), on the high side, within the range that was stated.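

Exchanging the halogen alone, on an aromatic carbon next to the ring oxygen, gives a 2.0-fold lower number from compound 2 to compound 3 (0.30 log units; within the scatter) in this assay, so this read-out does not tell bromo and chloro apart at this place. Putting 5-chlorofuran-2-yl in place of thiophen-2-yl gives an at least 5.5-fold lower number from compound 1 to compound 3 (0.74 log units; beyond the scatter), so the step seen with 5-bromofuran-2-yl recurs with a second halogen and does not depend on bromo alone. The full size of this step stays open, since compound 1 stands at a limit of the assay: the limit of > 1000 nM in this assay, at which 1 of the 3 values shown sits.

From the compounds shown here alone, how much of the step from thiophen-2-yl belongs to the ring oxygen and how much to the halogen remains open, as both change together; furan-2-yl without a halogen and 5-chlorothiophen-2-yl would separate the two. Also open, going by these compounds, is how this read-out responds at the same place to a group other than a halogen, such as methyl, a nitrile or an amine.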